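Swapping methoxy for dimethylamino in compound 4

The compounds below may be only part of what the source reports. "The series", "measured", "known", "first", "only" and "open" are said of these compounds alone.

Values in a functional assay on SiHa cells (Homo sapiens) for inhibition, read by sulforhodamine B assay; on this read-out lower numbers stand for stronger inhibition of growth and higher numbers for weaker inhibition of growth
- compound 1 `CN(C)c1ccc(-c2ccc(-c3ccc(-c4nc5ccccc5[nH]4)cc3)cc2)cc1` gives 100000 nM
- compound 2 `Oc1cccc2[nH]c(-c3ccc(-c4ccc(-c5ccc(OC(F)(F)F)cc5)cc4)cc3)nc12` gives 8410 nM
- compound 3 `COc1ccc(-c2ccc(-c3ccc(-c4nc5c(O)cccc5[nH]4)cc3)cc2)cc1` gives 4800 nM

In this assay compound 3 gives 4800 nM, which cannot be told apart from the value of compound 2 and is well under that of compound 1. Compound 4 `CN(C)c1ccc(-c2ccc(-c3ccc(-c4nc5c(O)cccc5[nH]4)cc3)cc2)cc1` has dimethylamino in place of methoxy on an aromatic carbon. Within the data shown here, the one measured step bearing on this, a 1.8-fold lower number from compound 2 to compound 3 (0.24 log units; within the scatter), stayed small. Compound 1 also carries dimethylamino and gives 100000 nM, but its core differs, so it suggests only a slight upward lean. The expected change is a 1.4-fold higher number from compound 3 to compound 4 (0.13 log units; within the scatter). Compound 4 is estimated at about 6500 nM, with an expected range of 1800 nM to 30000 nM.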

Compound 4, concentration for 50% growth inhibition: 6240 nM
Estimate against measurement, compound 4: 1.0-fold (0.02 log units) above; low and high end bracket the measured number.
By their numbers in this assay, from the lowest: compounds 3, 4 and 2 (each within the scatter of the next); then compound 1.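

In this assay the swap to dimethylamino from methoxy on this aromatic carbon gives a 1.3-fold higher number from compound 3 to compound 4 (0.11 log units; within the scatter) and the swap from trifluoromethoxy gives a 1.3-fold lower number from compound 2 to compound 4 (0.13 log units; within the scatter), so these three groups cannot be told apart here. With dimethylamino held constant, hydroxy in place of hydrogen on the core gives a 16-fold lower number from compound 1 to compound 4 (1.20 log units; beyond the scatter), a far larger step than either swap. No supporting evidence explains these results. As far as these compounds go, it remains open whether a carboxylic acid or a primary amine at this carbon would shift the number, and whether the hydroxy step would recur with methoxy in place.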